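From Methylsulfanyl to (Carboxymethyl)amino on the Chain Carbon

The source may hold more compounds than are shown below. What is called first, only, known or untested is meant among the compounds shown, and "the series" means these compounds.

Compound 1 `[N-]=[N+]=NCc1ncnc2c1ncn2[C@@H]1O[C@H](CO)[C@@H](O)[C@H]1O`: > 250000 nM (a limit)
Compound 2 `CN(Cc1ncnc2c1ncn2[C@@H]1O[C@H](CO)[C@@H](O)[C@H]1O)c1ccccc1`: 21000 nM
Compound 3 `CSCc1ncnc2c1ncn2[C@@H]1O[C@H](CO)[C@@H](O)[C@H]1O`: > 100000 nM (a limit)

All three compounds were tested in a functional assay on Huh-7 cells (Homo sapiens) for cytotoxicity, read by MTT assay, with a stated time of 3 days; a lower number here means that less compound is tolerated, a higher number that more compound is tolerated. Compound 3 gives > 100000 nM, which is a limit and not a number. Compound 4 `O=C(O)CNCc1ncnc2c1ncn2[C@@H]1O[C@H](CO)[C@@H](O)[C@H]1O` carries (carboxymethyl)amino in place of methylsulfanyl on a saturated chain carbon bound to an aromatic carbon.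

Within the data shown here, three measured steps concern this place. The two readable ones, an at least 11-fold lower number from compound 1 to compound 2 (1.07 log units; beyond the scatter) and an at least 4.7-fold higher number from compound 2 to compound 3 (0.67 log units; beyond the scatter), both involve the methyl(phenyl)amino group of compound 2, which compound 4 does not carry. The third is a step that the two limits leave unreadable from compound 1 to compound 3. No large change is therefore expected in this assay, and a further limit is likely. The expected step is a step that the limit leaves unreadable from compound 3 to compound 4. For compound 4 the estimate is 150000 nM, with an expected range from 60000 nM to 300000 nM.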

Compound 4, half-maximal cytotoxic concentration: > 100000 nM
Compound 4: no number, only a limit (the forecaster's own chance of this, stated with the estimate: 75%); the middle value lies beyond the limit too.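

In this assay compound 4 gives > 100000 nM, which is a limit and not a number. A nitrogen on the saturated chain carbon therefore does not by itself bring a measurable value, for there is an at least 4.7-fold higher number from compound 2 to compound 4 (0.67 log units; beyond the scatter), and methyl(phenyl)amino in compound 2 remains the only group shown that gives a number. The steps from compound 3 and from compound 1 to compound 4 cannot be read, as both ends are limits.

From the compounds shown here alone, it stays open whether dimethylamino or phenylamino on the same carbon would give a number, and so whether the phenyl ring or the methyl of compound 2 accounts for its step.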